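The source may report more compounds than this note shows. Statements on the series, on what has been measured and on what is new or still open speak of the compounds shown alone.

Measured compounds:
compound 1, `CNC(=O)/C=C/c1ccncc1-c1ccc2c(cnn2C)c1` – > 10000 nM
compound 2, `CNC(=O)CCc1ccncc1-c1ccc2ccccc2c1` – 8980 nM

Going by the values given here, in a functional assay on MDA-MB-231 cells (Homo sapiens) for inhibition, read by sulforhodamine B assay, with a stated time of 72 h (on this read-out higher numbers stand for weaker inhibition of growth and lower numbers for stronger inhibition of growth), compound 2 gives 8980 nM, and this is the only plain number among the two values shown. For compound 1 the result is a limit of the assay rather than a number, (the limit of > 10000 nM in this assay, at which 1 of the 2 values shown sits). So compound 2 stands as the single measured point from which the next compound is judged.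

Compound 3, `COC(=O)/C=C/c1ccncc1-c1ccc2ccccc2c1`, differs from compound 2 at one position: 2-(methoxycarbonyl)ethenyl in place of 2-(methylcarbamoyl)ethyl on an aromatic carbon. Among the compounds with values here, no step between two measured compounds is available that would show what such a change does in this assay, so the account rests on compound 2 alone. The step from compound 2 to compound 3 is expected to be small, a 1.1-fold lower number from compound 2 to compound 3 (0.05 log units; within the scatter), with no direction claimed beyond the scatter. Compound 3 is therefore estimated at 8000 nM in this assay, within a range from 2500 nM to 25000 nM.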

Compound 3, concentration for 50% growth inhibition: 4710 nM
Beside the measured number, compound 3's estimate is 1.7-fold (0.23 log units) above it; the range from low to high includes it.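

At this position, on an aromatic carbon opposite the ring nitrogen, putting 2-(methoxycarbonyl)ethenyl in place of 2-(methylcarbamoyl)ethyl gives a 1.9-fold lower number from compound 2 to compound 3 (0.28 log units; within the scatter) in this assay. This pair shows that a side chain with no hydrogen-bond donor and one more double bond outside aromatic rings can stand here with a value within the scatter of compound 2. Nothing shown gives a cause for this step.

As far as these compounds go, the donor and the double bond change together, so neither can be read alone, and what an amine, a carboxylic acid or a longer chain would give at this position stays open. Going by these compounds alone, compound 1 gives only a limit of the assay, > 10000 nM, and differs from the other two compounds in more than one place, so no step to it can be read.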